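Methylpiperazine for the piperidinyl ether in the sulfoxide series

This account rests on a few compounds, and the source may have more. Where it says the series, first, only, none or still open, it means among the compounds named here.

Of the compounds shown here, two have numbers so far in a functional assay on HCC827 cells (Homo sapiens) for antiproliferative activity, read by MTT assay, with a stated time of 72 h (a lower number here means a stronger inhibitor, a higher number a weaker inhibitor), and they sit close together. Compound 1 `CN1CCN(c2ccc(Nc3ncc4nc([S+]([O-])Cc5ccccc5)n(C5CCOCC5)c4n3)cc2)CC1` reads 433 nM there, and compound 2 `CN1CCC(Oc2ccc(Nc3ncc4nc([S+]([O-])c5ccccc5)n(C5CCOCC5)c4n3)cc2)CC1` reads 853 nM on the same read-out, which lies within the scatter of the value for compound 1. Compound 3 `CN1CCN(c2ccc(Nc3ncc4nc([S+]([O-])c5ccccc5)n(C5CCOCC5)c4n3)cc2)CC1` still awaits its number. It comes from compound 2 by a single change on an aromatic carbon, para to a large group: 4-methylpiperazin-1-yl in place of (1-methylpiperidin-4-yl)oxy on an aromatic carbon with the rest of the structure untouched.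

Going by the values given here, no measured pair shows this change alone, so its size in this assay cannot be read directly. The 4-methylpiperazin-1-yl group already stands in compound 1 at 433 nM and that value lies within the scatter of compound 2, so little movement is expected, at most a small shift towards a lower number. An estimated step of a 1.6-fold lower number from compound 2 to compound 3 (0.19 log units; within the scatter) is expected on this reasoning, no larger than the scatter. For compound 3 the estimated value is 550 nM with an expected range of 180 nM to 1600 nM in this read-out.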

Compound 3, half-maximal inhibitory concentration: 411 nM
Compound 3: the middle estimate sits 1.3-fold (0.13 log units) above what was measured; low and high end bracket the measured number.
By their numbers in this assay, from the lowest: compounds 3, 1 and 2 (each within the scatter of the next, the first and the last beyond it).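

In this assay the change of 4-methylpiperazin-1-yl in place of (1-methylpiperidin-4-yl)oxy now has a reading of its own, a 2.1-fold lower number from compound 2 to compound 3 (0.32 log units; beyond the scatter), a modest step that shows this aromatic carbon, para to a large group, does respond to the exchange of these two six-membered rings. With 4-methylpiperazin-1-yl held in place, phenyl in place of benzyl on the sulfur gives a 1.1-fold lower number from compound 1 to compound 3 (0.02 log units; within the scatter), so this pair shows no separation between the two sulfur substituents in this read-out. Nothing available on these compounds accounts for either step.

The compounds shown carry (1-methylpiperidin-4-yl)oxy only with phenyl on the sulfur, so it remains open whether the step between the two rings keeps its size with benzyl there. Also open, going by these compounds, is how the same aromatic carbon reads with a morpholin-4-yl group or a piperazin-1-yl group lacking the methyl, and whether the flat reading for phenyl and benzyl extends to a longer chain on the sulfur, such as 2-phenylethyl.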